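A few compounds are considered here, and "the series" means these few. Any claim that something is new, unique, unknown or untested is made for them only; others in the source may bear on it.

Among the measured compounds shown here, in a functional assay on HEK293 cells for agonist activity at Bile acid receptor (Homo sapiens), read by a luciferase reporter (on this read-out higher numbers stand for larger maximal responses and lower numbers for smaller maximal responses), compound 3 `CC(Oc1cccc(C(=O)O)c1)c1ccc(OCc2c(-c3c(Cl)cccc3Cl)noc2C2CC2)nc1C(F)(F)F` gives 49%, the largest of the three numbers measured so far, though its gap to compound 2 lies within the scatter. Compound 2 `O=C(O)c1ccc(OCc2ccc(OCc3c(-c4c(Cl)cccc4Cl)noc3C3CC3)nc2C(F)(F)F)cc1` gives 42%, and compound 1 `O=C(O)c1ccccc1OCc1ccc(OCc2c(-c3c(Cl)cccc3Cl)noc2C2CC2)nc1C(F)(F)F` gives 33%. The step of a number 16 percentage points higher from compound 1 to compound 3 (beyond the scatter) lies beyond the scatter, whereas a number 7 percentage points higher from compound 2 to compound 3 (within the scatter) does not. Compound 4 `CC(Oc1ccc(C(=O)O)cc1)c1ccc(OCc2c(-c3c(Cl)cccc3Cl)noc2C2CC2)nc1C(F)(F)F` differs from compound 3 by 4-carboxyphenyl in place of 3-carboxyphenyl on an oxygen on a saturated carbon. For the measured compounds named here, two measured steps bear on this change: a number 9 percentage points higher from compound 1 to compound 2 (within the scatter), which ends at the 4-carboxyphenyl that compound 4 carries, and a number 7 percentage points higher from compound 2 to compound 3 (within the scatter), which leads from it to the 3-carboxyphenyl of compound 3. Neither went beyond the scatter, so no change beyond the scatter is expected in this assay, and the step from compound 3 to compound 4 is expected to be a number 4 percentage points lower from compound 3 to compound 4 (within the scatter). Compound 4 is therefore expected to give 45%, between 32% and 58%.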

Compound 4, largest response reached (reported as efficacy), in percent of the reference or control that the assay uses: 33%
The estimate for compound 4 lay 12 percentage points above the measured number; measured number inside the range.
By their numbers in this assay, from the lowest: compounds 1, 4, 2 and 3 (each within the scatter of the next, the first and the last beyond it).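

In this assay, with the 1-(carboxyphenoxy)ethyl group held fixed, 4-carboxyphenyl in place of 3-carboxyphenyl on the oxygen gives a step beyond the scatter (a number 16 percentage points lower from compound 3 to compound 4 (beyond the scatter)). Methyl in place of hydrogen on the saturated chain carbon stays within the scatter (a number 9 percentage points lower from compound 2 to compound 4 (within the scatter)), as does the wider change (no change at the digits printed from compound 1 to compound 4 (within the scatter)), so with 4-carboxyphenyl in place the methyl shows no gain. Nothing available explains the difference between the two carboxyphenyl groups. Going by these compounds, it remains open how a (3-carboxyphenoxy)methyl group, without the methyl, would read, and whether a primary amide or a tetrazole could stand in for the carboxylic acid.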